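A few compounds are considered here, and "the series" means these few. Any claim that something is new, unique, unknown or untested is made for them only; others in the source may bear on it.

Measured in an ADME assay on MT4 cells (Homo sapiens) for cytotoxicity, read by MTT assay, with a stated time of 4 days; a higher number here means that more compound is tolerated, a lower number that less compound is tolerated:
- Compound 1 `Cc1cccc(NC(=O)CS(=O)(=O)c2nccc(Oc3c(C)cc(C#N)cc3C)n2)c1`: 25700 nM
- Compound 2 `COc1ccc(NC(=O)CS(=O)(=O)c2nccc(Oc3c(C)cc(C#N)cc3C)n2)cc1`: 5110 nM
- Compound 3 `Cc1cc(C#N)cc(C)c1Oc1ccnc(S(=O)(=O)CC(=O)Nc2ccccc2Cl)n1`: 12500 nM

In this assay, compound 3 holds the middle place of the three, with compound 1 higher and compound 2 lower. Compound 4 `Cc1cc(C#N)cc(C)c1Oc1ccnc(S(=O)(=O)CC(=O)Nc2ccc(Cl)cc2)n1` has not yet been measured. It has the same atoms as compound 3, joined differently: 4-chlorophenyl in place of 2-chlorophenyl on an amide-type nitrogen. In words, 4-chlorophenyl stands in place of 2-chlorophenyl on an amide-type nitrogen.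

Within the data shown here, no measured pair shows this exact change, so the nearest guide is what other swaps at that nitrogen have done. All three were modest: a 2.1-fold lower number from compound 1 to compound 3 (0.31 log units; beyond the scatter), a 2.4-fold higher number from compound 2 to compound 3 (0.39 log units; beyond the scatter) and a 5.0-fold lower number from compound 1 to compound 2 (0.70 log units; beyond the scatter). These steps run in both directions, and none of them shows what this particular change does. A step of similar or smaller size is therefore expected, with only a slight lean towards a lower number, and the direction remains uncertain. The expected change is a 1.4-fold lower number from compound 3 to compound 4 (0.14 log units; within the scatter). For compound 4, the estimated value is 9000 nM, with an estimated range from 3500 nM to 25000 nM.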

Compound 4, half-maximal cytotoxic concentration: 16600 nM
For compound 4 the middle estimate is 1.8-fold (0.27 log units) below the measured one, within the range that was stated.
By their numbers in this assay, from the lowest: compound 2; then compounds 3, 4 and 1 (each within the scatter of the next, the first and the last beyond it).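

In this assay, among these compounds, the first direct look at where the chlorine sits on this ring, 4-chlorophenyl in place of 2-chlorophenyl on the amide-type nitrogen gives a 1.3-fold higher number from compound 3 to compound 4 (0.12 log units; within the scatter) and so cannot be told apart from repeat-measurement noise. The group on the same ring carbon can be told apart: chloro in place of methoxy on an aromatic carbon gives a 3.2-fold higher number from compound 2 to compound 4 (0.51 log units; beyond the scatter), while 4-chlorophenyl in place of 3-methylphenyl gives a 1.5-fold lower number from compound 1 to compound 4 (0.19 log units; within the scatter) and stays inside the noise. No supporting data bear on why these steps differ in size.

Still open, from the compounds shown here alone, is how 3-chlorophenyl would compare with its two relatives. So is the effect of an amine or a carboxylic acid on this ring, or of a cyclohexyl group in place of the ring.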